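The source may hold more compounds than are shown below. What is called first, only, known or untested is meant among the compounds shown, and "the series" means these compounds.

Of the compounds shown here, three built on a shared core have been tested in a functional assay on the whole organism with Rattus norvegicus as the target; a lower number here means that less compound is needed, a higher number that more compound is needed for the effect. Compound 1 `Cc1nn(C)c2c1C(c1ccccc1Cl)=NCC(=O)N2` gives 16 mg/kg, compound 2 `CCc1nn(C)c2c1C(c1cccc(F)c1)=NCC(=O)N2C` gives 32 mg/kg, and compound 3 `CCn1nc(C)c2c1NC(=O)CN=C2c1ccccc1Cl` gives 8 mg/kg. The numbers of compound 3 and compound 1 lie within the scatter of each other, so no order between them is claimed, whereas compound 2 needs a larger dose than compound 3, beyond the scatter. Among the compounds with values here, the only step measured between compounds differing in one place, a 2.0-fold lower number from compound 1 to compound 3 (0.30 log units; within the scatter), concerns a site other than the one changed now.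

Compound 4 `C=CCN1C(=O)CN=C(c2ccccc2Cl)c2c(C)nn(CC)c21` differs from compound 3 in a single place: allyl in place of hydrogen on an amide-type nitrogen in a ring. Within the data shown here, no measured step isolates this amide-type nitrogen. Compound 2 carries a methyl on the same amide-type nitrogen, yet it also differs from compound 3 elsewhere, so its value cannot be tied to that one change. The expectation is therefore no step beyond the scatter, held with wide uncertainty. Compound 4 is expected to give about 12 mg/kg, between 4 mg/kg and 40 mg/kg, an estimated step of a 1.5-fold higher number from compound 3 to compound 4 (0.18 log units; within the scatter).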

Compound 4, minimum effective dose: 63 mg/kg
For compound 4 the middle estimate is 5.3-fold (0.72 log units) below the measured one, and the stated range ends below it.
By their numbers in this assay, from the lowest: compounds 3, 1, 2 and 4 (each within the scatter of the next, the first and the last beyond it).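

Placing allyl on the amide-type nitrogen raises the dose needed in this assay, with a 7.9-fold higher number from compound 3 to compound 4 (0.90 log units; beyond the scatter). Within the data shown here, this is the first measured step that isolates this position, and it shows that what sits on this ring nitrogen can matter: here, replacing the hydrogen moves the number beyond the scatter. Nothing measured on these compounds explains the rise.

One substituent cannot show whether the rise is particular to allyl or would follow from any group replacing the amide hydrogen, and the methyl on the same nitrogen in compound 2 does not settle this, as that compound also differs elsewhere. On the core of compound 3, a saturated propyl chain, a benzyl group or a chain ending in an amine would help separate these possibilities.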